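The source may hold more compounds than are shown below. What is called first, only, known or untested is meant among the compounds shown, and "the series" means these compounds.

Within the data shown here, compound 3 `CN(C)c1ccc(C2CC(c3ccccc3)=NN2C2=NC(=O)/C(=C3\C(=O)Nc4ccccc43)S2)cc1` is one of three compounds measured in a functional assay on cells (Leukemia cell, Homo sapiens) for cytotoxicity, read by sulforhodamine B assay, with a stated time of 48 h; a lower number here means a stronger inhibitor of growth, a higher number a weaker inhibitor of growth; in this assay compound 3 gives 33900 nM, the highest of the three numbers. Compound 1 `O=C1N=C(N2N=C(c3ccccc3)CC2c2ccccc2O)S/C1=C1/C(=O)Nc2ccc(Br)cc21` gives 270 nM in this assay, and compound 2 `COc1ccc(C2CC(c3ccccc3)=NN2C2=NC(=O)/C(=C3\C(=O)Nc4ccc(Br)cc43)S2)cc1` gives 250 nM; both of these numbers are far lower than that of compound 3, well beyond the scatter. Among the measured compounds shown here, the only single-place step measured is a 1.1-fold lower number from compound 1 to compound 2 (0.03 log units; within the scatter), which concerns a different part of the molecule and is within the scatter.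

Compound 4 `CN(C)c1ccc(C2CC(c3ccccc3)=NN2C2=NC(=O)/C(=C3\C(=O)Nc4ccc(Br)cc43)S2)cc1` differs from compound 3 by bromo in place of hydrogen on an aromatic carbon. For the measured compounds named here, no measured pair isolates this change: compounds 1 and 2 carry the bromo but also a different aryl group on the saturated ring carbon, so their gap to compound 3 combines two changes and cannot be split. The step from compound 1 to compound 2 suggests the aryl group matters little, which leaves the bromo as the remaining candidate for the large gap, but that is an inference, not a measurement.

Compound 4 is therefore expected to give a lower number than compound 3 in this assay, by about an 11-fold lower number from compound 3 to compound 4 (1.05 log units; beyond the scatter), with wide uncertainty. The estimate for compound 4 is 3000 nM, within a range of 400 nM to 25000 nM.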

Compound 4, concentration for 50% growth inhibition: 310 nM
Estimate against measurement, compound 4: 9.7-fold (0.99 log units) above, and the stated range ends above it.
By their numbers in this assay, from the lowest: compounds 2, 1 and 4 (each within the scatter of the next); then compound 3.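

In this assay, bromo in place of hydrogen on an aromatic carbon of the six-membered aromatic ring of carbon only gives a 110-fold lower number from compound 3 to compound 4 (2.04 log units; beyond the scatter), so the large effect of this one change now rests on a matched pair and no longer on inference. Once the bromo is present, the group on the saturated ring carbon shows little effect: the change of dimethylamino for methoxy gives a 1.2-fold higher number from compound 2 to compound 4 (0.09 log units; within the scatter), and the change of 4-(dimethylamino)phenyl for 2-hydroxyphenyl gives a 1.1-fold higher number from compound 1 to compound 4 (0.06 log units; within the scatter), both within the scatter. No measurement at hand offers an explanation for the size of the bromo step.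

The compounds shown leave open whether this step is particular to bromo or would also appear with chloro, fluoro, methyl or a nitrile on the same aromatic carbon. They also leave open whether bromo would give a step of similar size alongside 2-hydroxyphenyl or 4-methoxyphenyl on the saturated ring carbon, where the partners without bromo are not among the compounds shown here.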